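The compounds below may be only part of what the source reports. "The series", "measured", "known", "first", "only" and "open" are said of these compounds alone.

Measured in an ADME assay on microsomes from liver (Mus musculus) for metabolic stability, read by LC-MS, with a stated time of 10 min, tested at 0.5 uM; a higher number here means that more of the compound is left, a lower number that less of the compound is left:

Compound 1 `c1ccc2c(c1)CN[C@@H](CN(CCC1CCNCC1)[C@H]1CCCc3cccnc31)C2`: 32%
Compound 2 `c1cnc2c(c1)CCC[C@@H]2N(CCCN1CCNCC1)Cc1cc2ccccc2cn1`: 74%
Compound 3 `c1ccc2c(c1)CN[C@@H](CN(CCCN1CCN(C3CC3)CC1)[C@H]1CCCc3cccnc31)C2`: 3%

Compound 2, at 74%, has the highest number of the three, clearly ahead of compound 1 at 32% and compound 3 at 3%. The next compound, compound 4 `c1cnc(CN(CCCN2CCNCC2)[C@H]2CCCc3cccnc32)nc1`, differs from compound 2 as follows: pyrimidin-2-yl in place of isoquinolin-3-yl on a saturated chain carbon bound to an amine nitrogen. Pyrimidin-2-yl thus stands in place of isoquinolin-3-yl on a saturated chain carbon bound to an amine nitrogen.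

Among the measured compounds shown here, no measured step covers this change. For the measured compounds named here, the only one available is a number 29 percentage points lower from compound 1 to compound 3 (beyond the scatter), and it concerns a different exchange elsewhere in the molecule. It shows that numbers in this assay can move substantially within this series, but it gives no direction for the present change. The expected step is therefore a number 4 percentage points higher from compound 2 to compound 4 (within the scatter), which is none beyond the scatter, though with wide uncertainty. The estimate for compound 4 is 78%, with an expected range from 55% to 93%.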

Compound 4, percent of the compound remaining: 78%
The estimate for compound 4 equals the measured number at the digits printed, within the range that was stated.
By their numbers in this assay, from the lowest: compound 3; then compound 1; then compounds 2 and 4 (each within the scatter of the next).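

In this assay, the exchange of isoquinolin-3-yl for pyrimidin-2-yl on a saturated chain carbon bound to an amine nitrogen gives a number 4 percentage points higher from compound 2 to compound 4 (within the scatter). Among the compounds shown here, this is the first measured step at this place, and it shows that, in this pair, a group of 6 heavy atoms with one aromatic ring can stand in place of one of 10 heavy atoms with two aromatic rings without a change beyond the scatter. No evidence at hand explains this result.

On these data alone, whether the read-out would also hold with a phenyl, a pyridin-2-yl or a simple alkyl chain such as ethyl at this place remains open. As far as these compounds go, it is equally open whether the same exchange would give a similar step with a piperidine or another amine on the other chain.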